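This account rests on a few compounds, and the source may have more. Where it says the series, first, only, none or still open, it means among the compounds named here.

Measured in a functional assay on A549 cells (Homo sapiens) for cytotoxicity, read by MTT assay, with a stated time of 72 h; on this read-out higher numbers stand for weaker inhibition and lower numbers for stronger inhibition:
Compound 1 `O=C(CN1CCN(c2nnc(Cc3ccncc3)c3ccccc23)CC1)Nc1ccc(Br)cc1`: 2710 nM
Compound 2 `O=C(CN1CCN(c2nnc(Cc3ccccc3)c3ccccc23)CC1)Nc1ccc(F)c(C(F)(F)F)c1`: 2480 nM
Compound 3 `O=C(CN1CCN(c2nnc(Cc3ccncc3)c3ccccc23)CC1)Nc1ccc(F)c(C(F)(F)F)c1`: 16000 nM

Compound 2, at 2480 nM, lies within the usual scatter of compound 1, while the move to compound 3 is clear: a 6.5-fold higher number from compound 2 to compound 3 (0.81 log units; beyond the scatter). That step changes a different place, so it says little here. Compound 4 `O=C(CN1CCN(c2nnc(Cc3ccccc3)c3ccccc23)CC1)Nc1cc(C(F)(F)F)ccc1Cl` differs from compound 2 only on the amide-type nitrogen: 2-chloro-5-(trifluoromethyl)phenyl in place of 4-fluoro-3-(trifluoromethyl)phenyl on an amide-type nitrogen. Within the data shown here, the one measured swap at this place is a 5.9-fold higher number from compound 1 to compound 3 (0.77 log units; beyond the scatter). It shows that this place can shift the number, but it involves other groups and gives no direction for 2-chloro-5-(trifluoromethyl)phenyl. No change beyond the scatter is therefore expected in this assay, and the estimated step is a 1.2-fold higher number from compound 2 to compound 4 (0.08 log units; within the scatter), with real uncertainty either way. For compound 4 the expected value is 3000 nM, with an estimated range from 800 nM to 11000 nM.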

Compound 4, half-maximal inhibitory concentration: 89000 nM
Estimate against measurement, compound 4: 30-fold (1.47 log units) below; the measured number lies above the stated range.
By their numbers in this assay, from the lowest: compounds 2 and 1 (each within the scatter of the next); then compound 3; then compound 4.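

In this assay, the step at the amide-type nitrogen is large: a 36-fold higher number from compound 2 to compound 4 (1.55 log units; beyond the scatter). This shows that two aryl groups with the same count of heavy atoms and the same single aromatic ring of carbon only can give very different numbers, so the pattern of groups on this ring matters here, not just its size. Nothing measured here explains this result.

Going by these compounds, the chlorine and the changed pattern of the trifluoromethyl group arrive together, so their separate shares stay open. A plain phenyl or a methoxyphenyl on this nitrogen would give further reference points.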